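The source may report more compounds than this note shows. Statements on the series, on what has been measured and on what is new or still open speak of the compounds shown alone.

Of the compounds shown here, three have been tested in a functional assay on MCF7 cells (Homo sapiens) for inhibition, read by MTT assay, with a stated time of 72 h; on this read-out lower numbers stand for stronger inhibition and higher numbers for weaker inhibition. Compound 3 `Nc1nc2cc(-c3nn(CCCCCCCCC(=O)NO)c4ncnc(N)c34)ccc2o1` gives 42100 nM. For compound 1 `Nc1nc2cc(-c3nn(CCCCCCCCCC(=O)NO)c4ncnc(N)c34)ccc2o1` the result is only a limit of the assay, > 50000 nM. For compound 2 `Nc1ncnc2c1c(-c1cnc3[nH]ccc3c1)nn2CCC(=O)NO` the result is again only a limit, > 150000 nM. Compound 4 `Nc1ncnc2c1c(-c1cnc3[nH]ccc3c1)nn2CCCC(=O)NO` has not yet been measured in this assay.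

Compound 1 differs from compound 3 by (hydroxycarbamoyl)methyl in place of hydroxycarbamoyl on a saturated chain carbon, eight bonds along the chain from an aromatic nitrogen. The measured step is an at least 1.1-fold higher number from compound 3 to compound 1 (0.07 log units; that floor lies within the scatter); its floor comes about because compound 1 sits at a limit (the limit of > 50000 nM in this assay, at which 1 of the 3 values shown sits). The same kind of change, with the chain cut at a different point, separates compound 4 from compound 2: (hydroxycarbamoyl)methyl in place of hydroxycarbamoyl on a saturated chain carbon, two bonds along the chain from an aromatic nitrogen. The two place lines differ in how far along the chain from the aromatic nitrogen the group sits, two bonds in compound 2 against eight bonds in compound 3. The difference between the core of compound 2 and the core of compound 3 is not broken down here.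

Going by the values given here, for compound 4 the expected step is an at least 1.2-fold lower number from compound 2 to compound 4 (0.09 log units; that floor lies within the scatter), because compound 2 itself stands only at a limit (the limit of > 150000 nM in this assay, at which 1 of the 3 values shown sits), and the one measured step of this kind is small. The estimate for compound 4 in this assay is therefore 120000 nM, with a range from 30000 nM to 400000 nM.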

Compound 4, half-maximal inhibitory concentration: > 150000 nM
Compound 4: a limit, no number (the forecaster's own chance of this, stated with the estimate: 65%); middle value at least 1.2-fold (0.09 log units) from the limit.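

Compound 2 and compound 4 both stand only at a limit of the assay, so no step between them can be read: the limit of > 150000 nM in this assay, at which 2 of the 4 values shown sit.

The compounds shown leave open how much (hydroxycarbamoyl)methyl in place of hydroxycarbamoyl changes the number on the core of compound 2, and whether that change matches the one on the core of compound 3.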